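A few compounds are considered here, and "the series" means these few. Any claim that something is new, unique, unknown or untested is made for them only; others in the source may bear on it.

Measured so far:
compound 1, `COc1cc(C(N)=O)nn1-c1ccccc1`: 34.3%
compound 2, `CNC(=O)c1cc(OC)n(-c2ccccc2)n1`: 57.9%

In a functional assay on the whole organism (strain Wistar) for inhibition, with Rattus norvegicus as the target, read by paw edema, with stated times of 30 min and 3 h, at a dose of 100 mg/kg by the oral route (on this read-out lower numbers stand for less inhibition and higher numbers for more inhibition at the one dose given (going by the name of the read-out)), compound 1 gives 34.3% and compound 2 gives 57.9%. Compound 2 thus stands highest of the two numbers, the gain a number 23.6 percentage points higher from compound 1 to compound 2 (beyond the scatter) lying beyond the scatter. Compound 3, `COc1cc(C(=O)N(C)C)nn1-c1ccccc1`, carries the change (methyl in place of hydrogen on an amide-type nitrogen). Among the measured compounds shown here, the only step of this kind is a number 23.6 percentage points higher from compound 1 to compound 2 (beyond the scatter), a modest rise; a second methyl on the same nitrogen need not repeat it. Compound 3 is therefore expected to show a small upward step, a number 4.1 percentage points higher from compound 2 to compound 3 (within the scatter), possibly within the scatter. Compound 3 is estimated at 62%, within 42% to 80%.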

Compound 3, a percentage reported as inhibition, in the whole organism at one dose (the size of the read-out at that dose, not a potency): 47.5%
The estimate for compound 3 lay 14.5 percentage points above the measured number; measured number inside the range.
By their numbers in this assay, from the lowest: compound 1; then compound 3; then compound 2.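

In this assay a second methyl on the amide-type nitrogen does not extend the earlier gain: the change gives a number 10.4 percentage points lower from compound 2 to compound 3 (beyond the scatter), so the same swap of hydrogen for methyl that raised the number once now lowers it. Going from amino to dimethylamino still leaves a net gain, a number 13.2 percentage points higher from compound 1 to compound 3 (beyond the scatter), which places the best number here on the singly methylated amide. Nothing available explains why the two methyl steps run in opposite directions. The compounds shown leave open whether an ethyl group on this nitrogen, or a cyclic amine such as morpholine in place of dimethylamino, would match compound 2 or fall further.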